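Sulfoxide-bearing chromone esters: isopropyl to propyl exchange

The source may report more compounds than this note shows. Statements on the series, on what has been measured and on what is new or still open speak of the compounds shown alone.

Measured compounds:
compound 1 `CC(C)C(=O)Oc1ccc2oc(/C=C/[S+](C)[O-])cc(=O)c2c1` — 9100 nM
compound 2 `Cc1c(/C=C/[S+](C)[O-])oc2ccccc2c1=O` — 7200 nM

Both compounds were tested in a functional assay on DLD-1 cells (Homo sapiens) for cytotoxicity, with a stated time of 48 h; on this read-out lower numbers stand for stronger inhibition and higher numbers for weaker inhibition. Compound 1 gives 9100 nM, the higher of the two numbers recorded. Among the measured compounds shown here, compound 2 gives 7200 nM; the gap to compound 1 is within the scatter, so the two are read as equivalent, and no ordering of the pair is claimed. The structures of compound 1 and compound 2 differ in more than one place, so nothing is drawn from their comparison beyond this.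

The next compound is compound 3 `CCCC(=O)Oc1ccc2oc(/C=C/[S+](C)[O-])cc(=O)c2c1`. Its relation to compound 1 is a single exchange: propyl in place of isopropyl on a carbonyl carbon. The two structures hold the same atoms, joined differently. For the measured compounds named here, no measured pair isolates this kind of change, so there is no precedent to lean on. The working expectation is a step from compound 1 to compound 3 of a 1.0-fold lower number from compound 1 to compound 3 (0.00 log units; within the scatter), that is, no change beyond the scatter. Compound 3 is therefore estimated at 9000 nM, within 4500 nM to 18000 nM.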

Compound 3, half-maximal inhibitory concentration: 8700 nM
The estimate for compound 3 lay 1.0-fold (0.01 log units) above the measured number; low and high end bracket the measured number.
By their numbers in this assay, from the lowest: compounds 2, 3 and 1 (each within the scatter of the next).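

In this assay, among the compounds shown here, propyl in place of isopropyl on a carbonyl carbon gives a 1.0-fold lower number from compound 1 to compound 3 (0.02 log units; within the scatter), the only step that isolates this position. Compound 1 and compound 3 are therefore read as equivalent: at this position, the arrangement of these three carbon atoms as isopropyl or propyl is not distinguished by this read-out. No available evidence explains this equivalence.

A single pair with the same atoms does not show whether the read-out responds to any other group at this position, so the equivalence holds only for isopropyl and propyl. A longer chain such as hexyl, or a group of another kind such as an amine or a carboxylic acid, on this carbonyl carbon would test how far it extends.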